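The source may hold more compounds than are shown below. What is called first, only, known or untested is meant among the compounds shown, and "the series" means these compounds.

Compound 1 `O=C(CNC(=O)c1ccccc1)NC(c1ccccc1)c1ccc(Cl)cc1`: 390 nM
Compound 2 `O=C(CNC(=O)c1ccc(Cl)cc1)NC(c1ccccc1)c1ccc(Cl)cc1`: 150 nM; 300 nM; 280 nM (3 entries)
Compound 3 `O=C(CNC(=O)c1ccc(F)cc1)NC(c1ccccc1)c1ccc(Cl)cc1`: 88 nM; 88 nM (2 entries)

All three compounds were tested in an assay for inhibition of sodium- and chloride-dependent glycine transporter 1 (Homo sapiens); a lower number here means that less compound is needed, a higher number that more compound is needed for the effect. Compound 1 is the only one of the three that comes with a single measurement, so its value stands alone; compound 2 and compound 3 each have several entries. Compound 2 shows how far repeated entries of one compound can spread, as the several entries of compound 2 in this assay, 150 nM; 300 nM; 280 nM (3 entries) makes plain, and its entries sit lower than the value of compound 1. Compound 3 sits lower still, with both of its entries in agreement. Within the data shown here, compound 1, with its single number, is the weakest-looking of the three in this assay, though only one measurement supports that.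

Compound 4 `O=C(CNC(=O)c1ccsc1)NC(c1ccccc1)c1ccc(Cl)cc1` is not yet measured. It differs from compound 1 in one place: thiophen-3-yl in place of phenyl on a carbonyl carbon. The rest of the shared core is untouched. Nothing in the measured set swaps the ring on this carbonyl for a different ring. Among the measured compounds shown here, there is thus no measured step to lean on for this change; the available steps only vary a substituent on the phenyl. Such a swap of one small aromatic ring for another of similar shape is expected to move the value little, if at all, beyond the scatter. Compound 4 is therefore estimated at 350 nM, within a range of 150 nM to 850 nM. The step this implies is expected to be a 1.1-fold lower number from compound 1 to compound 4 (0.05 log units; within the scatter), essentially flat.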

Compound 4, half-maximal effective concentration: 89 nM
Compound 4: the middle estimate sits 3.9-fold (0.59 log units) above what was measured; the whole stated range lies above it.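

Swapping the whole ring on this carbonyl carbon matters: in this assay, thiophen-3-yl in place of phenyl gives a 4.4-fold lower number from compound 1 to compound 4 (0.64 log units; beyond the scatter). The earlier compounds shown here all keep a phenyl ring here and vary only its substituent, so they could not show that the ring itself can be exchanged with a clear change in the number. One caution is that compound 1 rests on a single entry, and repeated entries of one compound can spread, as the following shows: the several entries of compound 2 in this assay, 150 nM; 300 nM; 280 nM (3 entries)

One swap changes ring size and brings in a sulfur atom at the same time, so these compounds cannot separate the two or say why the number falls. Still open, on these data alone, is how other rings on this carbonyl carbon would compare, such as thiophen-2-yl, furan-3-yl, pyridin-3-yl or a saturated cyclohexyl ring, and whether a chlorine or fluorine atom added to the thiophene ring would change the number further.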